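The compounds below may be only part of what the source reports. "The series", "measured", "known", "first", "only" and "open" are said of these compounds alone.

In a functional assay on HUVEC cells (Homo sapiens), read by scintillation counting and thymidine incorporation, with a stated time of 24 h (a higher number here means a weaker inhibitor, a lower number a stronger inhibitor), three compounds that share one core have been measured. Compound 1 `CCC(C)n1ncn(-c2ccc(N3CCN(c4ccc(OC[C@@H]5CO[C@@](CC)(c6ccc(Cl)cc6Cl)O5)cc4)CC3)cc2)c1=O` gives 353 nM, compound 2 `CCC(C)n1ncn(-c2ccc(N3CCN(c4ccc(OC[C@@H]5CO[C@@](CC6CCCC6)(c6ccc(Cl)cc6Cl)O5)cc4)CC3)cc2)c1=O` gives 512 nM, and compound 3 `CCC(C)n1ncn(-c2ccc(N3CCN(c4ccc(OC[C@@H]5CO[C@@](Cn6nnnc6C)(c6ccc(Cl)cc6Cl)O5)cc4)CC3)cc2)c1=O` gives 101 nM. That last number is the lowest of the three, which makes compound 3 the strongest inhibitor so far.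

Compound 4 `CCC(C)n1ncn(-c2ccc(N3CCN(c4ccc(OC[C@@H]5CO[C@@](Cn6nnnc6-c6ccccc6)(c6ccc(Cl)cc6Cl)O5)cc4)CC3)cc2)c1=O` changes compound 3 in one place, with phenyl in place of methyl on an aromatic carbon. The 5-methyl-1H-tetrazol-1-yl group thus becomes 5-phenyl-1H-tetrazol-1-yl.

Going by the values given here, no measured step makes this exact swap, so the evidence is indirect. Cyclopentyl in place of methyl on the saturated chain gave a 1.5-fold higher number from compound 1 to compound 2 (0.16 log units; within the scatter), so a larger carbon group did not shift the number measurably there. Introducing 5-methyl-1H-tetrazol-1-yl gave a 3.5-fold lower number from compound 1 to compound 3 (0.54 log units; beyond the scatter) and a 5.1-fold lower number from compound 2 to compound 3 (0.70 log units; beyond the scatter), and compound 4 keeps that ring.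

A small rise within the scatter is therefore expected, and the estimate is a 1.5-fold higher number from compound 3 to compound 4 (0.17 log units; within the scatter). For compound 4 the estimated value is 150 nM, with an expected range from 50 nM to 450 nM.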

Compound 4, half-maximal inhibitory concentration: 119 nM
The estimate for compound 4 lay 1.3-fold (0.10 log units) above the measured number, and the stated range covers the measured number.
By their numbers in this assay, from the lowest: compounds 3 and 4 (each within the scatter of the next); then compounds 1 and 2 (each within the scatter of the next).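

In this assay, the aromatic carbon of the five-membered aromatic ring with 4 nitrogen carries phenyl in place of methyl with no measurable shift: a 1.2-fold higher number from compound 3 to compound 4 (0.07 log units; within the scatter), even though the group grows from 1 heavy atom to 6 heavy atoms and gains a six-membered aromatic ring. The advantage of the tetrazole-bearing side chain also holds with the larger group, with a 3.0-fold lower number from compound 1 to compound 4 (0.47 log units; beyond the scatter) and a 4.3-fold lower number from compound 2 to compound 4 (0.63 log units; beyond the scatter), both beyond the scatter. No measurement here explains why this position accepts the change.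

The compounds shown place only methyl and phenyl on this carbon, so it remains open how far the tolerance extends to a plain hydrogen, an amine, a carboxylic acid or a longer chain. On these data alone, it is also open whether a chloro group on the new phenyl would move the number.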